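This account rests on a few compounds, and the source may have more. Where it says the series, first, only, none or still open, it means among the compounds named here.

Of the compounds shown here, three have been tested in an assay on CHO cells for displacement of a labelled ligand from adenosine receptor A1 (Homo sapiens), read by scintillation counting, with a stated time of 90 min, in the presence of a further agent that is not named here; a higher number here means a weaker inhibitor, a lower number a stronger inhibitor. Among the measured compounds shown here, compound 1, with the structure `CCCn1c(=O)[nH]c2nc(-c3ccc(S(=O)(=O)N4CCN(Cc5cccc(Br)c5)CC4)cc3)[nH]c2c1=O`, gives 928 nM; this is the only value that comes as a number. Compound 2, with the structure `CCCn1c(=O)c2[nH]c(-c3ccc(S(=O)(=O)N4CCN(c5ccc(Cl)cc5)CC4)cc3)nc2n(CC)c1=O`, reaches only the limit of the assay, reported as > 1000 nM. Compound 3, with the structure `CCCn1c(=O)[nH]c2nc(-c3ccc(S(=O)(=O)N4CCN(c5ccccc5)C(C)C4)cc3)[nH]c2c1=O`, likewise reaches only the limit, reported as > 1000 nM. So the picture is the limit of > 1000 nM in this assay, at which 2 of the 3 values shown sit, and compound 1 alone gives a measured number to build on.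

Compound 4, with the structure `CCCn1c(=O)[nH]c2nc(-c3ccc(S(=O)(=O)N4CCN(Cc5ccc(Br)cc5)CC4)cc3)[nH]c2c1=O`, has not yet been measured. It differs from compound 1 in a single place: 4-bromophenyl in place of 3-bromophenyl on a saturated chain carbon bound to an amine nitrogen in a ring. The two molecules hold the same atoms, joined differently.

For the measured compounds named here, no measured pair of compounds differs in one place, so the size of this step cannot be read off any earlier result. The expectation is that the step of a 1.0-fold lower number from compound 1 to compound 4 (0.01 log units; within the scatter) stays inside the usual scatter of this assay, in neither direction. Compound 4 is therefore expected to give about 900 nM in this assay, with a likely range from 400 nM to 2500 nM.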

Compound 4, inhibition constant: > 1000 nM
Compound 4 ended at the assay's limit; the forecaster's own chance of this, stated with the estimate: 35%; middle value at least 1.1-fold (0.04 log units) from the limit.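

Among the compounds shown here, putting 4-bromophenyl in place of 3-bromophenyl on a saturated chain carbon bound to an amine nitrogen in a ring gives the first step that can be read in this set, in this assay (an at least 1.0-fold higher number from compound 1 to compound 4 (0.03 log units; that floor lies within the scatter)). As far as these compounds go, compound 4 gives > 1000 nM as a limit of the assay, not a number, so the step is only a floor and its true size remains unknown. For the compounds shown here, compound 1 now has a neighbour that differs in one place, yet that neighbour joins the other compounds at the limit, leaving compound 1 still the only measured number: the limit of > 1000 nM in this assay, at which 3 of the 4 values shown sit.

From the compounds shown here alone, how far compound 4 lies past the limit stays open. Also open, going by these compounds, is whether another group at this place, such as a pyridine ring or a carboxylic acid in place of the bromophenyl, would give a lower number than compound 1.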